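The source may hold more compounds than are shown below. What is called first, only, known or untested is meant among the compounds shown, and "the series" means these compounds.

Three compounds of this series have been put through a functional assay on PC-3 cells (Homo sapiens) for inhibition, read by sulforhodamine B assay, with a stated time of 48 h, tested at 50 uM; on this read-out higher numbers stand for more inhibition of growth at the one concentration tested and lower numbers for less inhibition of growth. Compound 1, `COc1ccccc1/C=C/C(=O)/C=C/c1ccc(OCc2cn(CCOc3cc(=O)oc4ccccc34)nn2)c(OC)c1`, gives 11% in this assay. Compound 2, `COc1ccc(/C=C/C(=O)/C=C/c2ccc(OCc3cn(CCCOc4cc(=O)oc5ccccc45)nn3)c(OC)c2)cc1OC`, gives 9% in this assay, and this number and that of compound 1 lie within the usual scatter of each other, so neither can be set above the other. Compound 3, `COc1cccc(/C=C/C(=O)/C=C/c2ccc(OCc3cn(CCCCOc4cc(=O)oc5ccccc45)nn3)c(OC)c2)c1`, is reported as "not active" (no number reported) in this assay, with no number given. Compound 1 thus stands among low readings throughout; nothing in the set reaches a strong inhibition of growth.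

Compound 4, `COc1cc(/C=C/C(=O)/C=C/c2cccs2)ccc1OCc1cn(CCOc2cc(=O)oc3ccccc23)nn1`, has not yet been measured. It differs from compound 1 in one place: thiophen-2-yl in place of 2-methoxyphenyl on a double-bonded chain carbon bound to a double-bonded chain carbon. Going by the values given here, no measured pair in the set shows this change, so its effect cannot be read from the data. Given that every measured compound sits low in this assay, compound 4 is expected to stay in that region, and the step is estimated as a number 1 percentage points lower from compound 1 to compound 4 (within the scatter), not beyond the scatter. Compound 4 is accordingly expected to give about 10% in this assay, with a range from 0% to 25%.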

Compound 4, percent growth inhibition at one concentration: 12%
For compound 4 the middle estimate is 2 percentage points below the measured one, and the stated range covers the measured number.
By their numbers in this assay, from the lowest: compounds 2, 1 and 4 (each within the scatter of the next).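

The exchange of 2-methoxyphenyl for thiophen-2-yl on a double-bonded chain carbon bound to a double-bonded chain carbon reads in this assay as a number 1 percentage points higher from compound 1 to compound 4 (within the scatter). Going by these compounds alone, this is the first comparison in the set that isolates one place, and on this read-out the six-membered carbon ring and the five-membered ring with sulfur cannot be told apart. Both compounds remain at low inhibition of growth, and no measurement here bears on why the two groups read alike.

The compounds shown leave open whether any group at this place, such as a phenyl ring carrying an amine or a carboxylic acid, would lift the reading clear of the low region. They also leave open what a longer chain does on its own, since compound 2 and compound 3 differ from compound 1 in more than one place.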